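A few compounds are considered here, and "the series" means these few. Any claim that something is new, unique, unknown or untested is made for them only; others in the source may bear on it.

Compound 3 `COc1ccccc1-c1nnc(-c2ccc(C(=O)N/N=C/c3c(O)cc(O)cc3O)cc2)o1` gives 12400 nM in an ADME assay on THP-1 cells (Homo sapiens) for cytotoxicity (on this read-out lower numbers stand for stronger inhibition and higher numbers for weaker inhibition), the lowest of the three numbers recorded. Compound 2 `COc1ccccc1-c1nnc(-c2ccc(C(=O)N/N=C/c3ccc(Cl)cc3Cl)cc2)o1` gives 78800 nM, so that a 6.4-fold lower number from compound 2 to compound 3 (0.80 log units; beyond the scatter). Compound 1 `COc1ccccc1-c1nnc(-c2ccc(C(=O)N/N=C/c3ccccc3O)cc2)o1` gives 207000 nM; here a 17-fold lower number from compound 1 to compound 3 (1.22 log units; beyond the scatter), the largest step seen, while a 2.6-fold lower number from compound 1 to compound 2 (0.42 log units; beyond the scatter). Compound 4 `COc1ccc(/C=N/NC(=O)c2ccc(-c3nnc(-c4ccccc4OC)o3)cc2)cc1O` carries 3-hydroxy-4-methoxyphenyl in place of 2,4,6-trihydroxyphenyl on a carbon with a double bond to nitrogen. Every measured step altered this same group, and the trihydroxy group brought the largest fall in number, so a group with a single hydroxyl and a methoxy in its place is expected to give much of that back. Compound 4 is therefore expected to show a rise, a 4.8-fold higher number from compound 3 to compound 4 (0.68 log units; beyond the scatter). The estimate for compound 4 in this assay is 60000 nM, with a range from 15000 nM to 200000 nM.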

Compound 4, half-maximal inhibitory concentration: 260000 nM
The estimate for compound 4 lay 4.3-fold (0.64 log units) below the measured number; the whole stated range lies below it.
By their numbers in this assay, from the lowest: compound 3; then compound 2; then compounds 1 and 4 (each within the scatter of the next).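

At this place, on a carbon with a double bond to nitrogen, carrying a hydroxyl is not enough to lower the number in this assay: 3-hydroxy-4-methoxyphenyl in place of 2,4,6-trihydroxyphenyl gives a 21-fold higher number from compound 3 to compound 4 (1.32 log units; beyond the scatter), the largest step seen. The same group in place of 2-hydroxyphenyl gives a 1.3-fold higher number from compound 1 to compound 4 (0.10 log units; within the scatter), so these two groups cannot be told apart, while in place of 2,4-dichlorophenyl it gives a 3.3-fold higher number from compound 2 to compound 4 (0.52 log units; beyond the scatter). Going by these compounds, whether the low number of compound 3 needs all three hydroxyls, and how an amine or a carboxylic acid on this ring would behave, stays open. Nothing available accounts for these steps.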